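Chain extension on two diphenylpyridazine series

The source may hold more compounds than are shown below. What is called first, only, known or untested is meant among the compounds shown, and "the series" means these compounds.

Measured so far:
compound 1 `CCCCCCCOc1cc(-c2ccccc2)c(-c2ccccc2)nn1`, 58000 nM
compound 2 `CCCCCCCCOc1cc(-c2ccccc2)c(-c2ccccc2)nn1`, 104000 nM
compound 3 `CCCCCCCC[S+]([O-])c1cc(-c2ccccc2)c(-c2ccccc2)nn1`, 92000 nM

All three numbers come from an assay on microsomes from liver for inhibition of sterol O-acyltransferase 1 (Rattus norvegicus); on this read-out lower numbers stand for stronger inhibition and higher numbers for weaker inhibition. Compound 1 and compound 2 differ by methyl in place of hydrogen on a saturated chain carbon, seven bonds along the chain from an oxygen on an aromatic ring; the step is a 1.8-fold higher number from compound 1 to compound 2 (0.25 log units; within the scatter). Compound 3 carries a different core; how it differs from the core of compound 1 is not broken down here. Its value sits close to that of compound 2 and that of compound 1, all within the scatter of one another.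

Compound 4 `CCCCCCCCC[S+]([O-])c1cc(-c2ccccc2)c(-c2ccccc2)nn1` is not yet measured in this assay. It differs from compound 3 by methyl in place of hydrogen on a saturated chain carbon, eight bonds along the chain from a sulfur. This is the same kind of change as that from compound 1 to compound 2, with one difference around the place: in the earlier pair the chain carbon stands seven bonds along the chain from an oxygen on an aromatic ring, here eight bonds along the chain from a sulfur. Among the compounds with values here, with only one earlier example, itself within the scatter, the step from compound 3 to compound 4 is expected to be small and of the same direction, a 1.4-fold higher number from compound 3 to compound 4 (0.15 log units; within the scatter). Compound 4 is estimated at 130000 nM, likely between 60000 nM and 300000 nM.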

Compound 4, half-maximal inhibitory concentration: 87000 nM
Beside the measured number, compound 4's estimate is 1.5-fold (0.17 log units) above it; the measured number falls inside the stated range.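

In this assay, methyl in place of hydrogen on a saturated chain carbon, eight bonds along the chain from a sulfur, gives a 1.1-fold lower number from compound 3 to compound 4 (0.02 log units; within the scatter). Set beside the earlier step on the other core, the new step cannot be told apart from it: the same change on two cores in this assay, a 1.8-fold higher number (0.25 log units; within the scatter) from compound 1 to compound 2 and a 1.1-fold lower number (0.02 log units; within the scatter) from compound 3 to compound 4, 1.9-fold (0.28 log units) apart, within the scatter of two such steps. Neither core gives this change a readable effect on the number, but that does not show that the two cores answer alike: two steps this small cannot separate them, and one pair per core fixes no trend with chain length.

The compounds shown leave open whether a longer chain, or a chain ending in an amine or a carboxylic acid, would give a step beyond the scatter on either core. Also open, as far as these compounds go, is whether the same change further down the chain, such as propyl to butyl, would carry from one core to the other.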